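Changing the piperidine substituent: from indolyl to fluorobenzoyl

The compounds below may be only part of what the source reports. "The series", "measured", "known", "first", "only" and "open" are said of these compounds alone.

Measured compounds:
compound 1 `CC1CCN(CC[C@H]2CCCN2S(=O)(=O)c2ccc3cc[nH]c3c2)CC1` with 2.4 nM
compound 2 `O=S(=O)(c1ccc2cc[nH]c2c1)N1CCC[C@@H]1CCN1CCC(c2cc3ccccc3[nH]2)CC1` with 6.31 nM

For the measured compounds named here, compound 2 `O=S(=O)(c1ccc2cc[nH]c2c1)N1CCC[C@@H]1CCN1CCC(c2cc3ccccc3[nH]2)CC1` gives 6.31 nM in an assay on HEK293 cells for binding affinity to 5-hydroxytryptamine receptor 7 (Homo sapiens), read by radioligand binding (a lower number here means a stronger inhibitor, a higher number a weaker inhibitor), the higher of the two numbers so far; its nearest neighbour is compound 1 `CC1CCN(CC[C@H]2CCCN2S(=O)(=O)c2ccc3cc[nH]c3c2)CC1`, which gives 2.4 nM in this assay. Going by the values given here, the one step recorded, a 2.6-fold higher number from compound 1 to compound 2 (0.42 log units; beyond the scatter), shows that a 1H-indol-2-yl group in place of methyl on the saturated ring carbon costs a modest amount of binding.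

Compound 3 `O=C(c1ccc(F)cc1)C1CCN(CC[C@H]2CCCN2S(=O)(=O)c2ccc3cc[nH]c3c2)CC1` carries the change ((4-fluorophenyl)carbonyl in place of 1H-indol-2-yl on a saturated ring carbon). Among the compounds with values here, no measured step covers this exact exchange; the only guide is that a large group on that ring carbon, in the step from compound 1 to compound 2, moved the number modestly and that a group of similar size now replaces it. Compound 3 is therefore expected to land near compound 2, with a 1.1-fold lower number from compound 2 to compound 3 (0.02 log units; within the scatter) not expected to exceed the scatter in either direction. The estimate for compound 3 in this assay is 6 nM, within a range of 2 nM to 18 nM.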

Compound 3, inhibition constant: 0.832 nM
Compound 3: the middle estimate sits 7.2-fold (0.86 log units) above what was measured; the measured number lies below the stated range.
By their numbers in this assay, from the lowest: compound 3; then compound 1; then compound 2.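

In this assay, the step of a 7.6-fold lower number from compound 2 to compound 3 (0.88 log units; beyond the scatter) shows that the number at this saturated ring carbon depends on which large group is attached, not on the heavy-atom count alone, as 1H-indol-2-yl and (4-fluorophenyl)carbonyl each have 9 heavy atoms. The step of a 2.9-fold lower number from compound 1 to compound 3 (0.46 log units; beyond the scatter) adds that a large group here need not give a higher number than methyl, since compound 2 goes one way from compound 1 and compound 3 the other. The exchange also replaces a group with 1 hydrogen-bond donor and 0 hydrogen-bond acceptors by one with 0 donors and 1 acceptor, but nothing available links this or any other feature of the two groups to the lower number.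

The compounds shown leave open whether the lower number goes with the carbonyl, the fluorine or the phenyl ring, which a plain benzoyl group or a 4-fluorobenzyl group on the same ring carbon would help to separate. They also leave open whether a 4-fluorophenyl group attached directly to that ring carbon would keep the number of compound 3 in this assay.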